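The source may hold more compounds than are shown below. What is called first, only, known or untested is meant among the compounds shown, and "the series" means these compounds.

The measured compounds in an assay on HEK293 cells for inhibition of Steryl-sulfatase (Homo sapiens), tested at 0.1 uM; a lower number here means a weaker effect, a higher number a stronger effect of the compound at the concentration tested:
compound 1 `CCN(Cc1ccccn1)c1cccc(C(=O)N2CCc3ccc(OS(N)(=O)=O)cc3C2)c1` gives 6.5%,
compound 2 `CN(C)CCCN(Cc1ccccc1)c1cccc(C(=O)N2CCc3ccc(OS(N)(=O)=O)cc3C2)c1` gives 23.8%,
compound 3 `CCN(Cc1ccc(F)cc1)c1cccc(C(=O)N2CCc3ccc(OS(N)(=O)=O)cc3C2)c1` gives 10.9%.

Compound 3 stands second highest of the three in this assay: compound 1 lies within the scatter of it, while compound 2 lies beyond the scatter above it. Compound 4 `CCCN(Cc1ccccc1)c1cccc(C(=O)N2CCc3ccc(OS(N)(=O)=O)cc3C2)c1` differs from compound 3 by benzyl(propyl)amino in place of ethyl(4-fluorobenzyl)amino on an aromatic carbon. Among the compounds with values here, the only measured step touching this part of the shared core, a number 4.4 percentage points higher from compound 1 to compound 3 (within the scatter), stayed within the scatter, so a further exchange at the same place is expected to move the read-out in this assay by no more than the scatter, in no clear direction. Compound 4 is therefore estimated at 12%, in a range from 2% to 25%. The expected step is a number 1.1 percentage points higher from compound 3 to compound 4 (within the scatter).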

Compound 4, a percentage reported as inhibition, at one concentration (the size of the read-out at that concentration, not a potency): 23.1%
Compound 4: middle estimate off by 11.1 percentage points, on the low side; measured number inside the range.
By their numbers in this assay, from the lowest: compounds 1 and 3 (each within the scatter of the next); then compounds 4 and 2 (each within the scatter of the next).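

In this assay, within the data shown here, this place on the aromatic ring proves able to respond to an exchange: it gives a number 12.2 percentage points higher from compound 3 to compound 4 (beyond the scatter) and a number 16.6 percentage points higher from compound 1 to compound 4 (beyond the scatter) and so moves further than the one earlier step did. Hydrogen in place of the dimethylamino end of the chain in compound 2 gives a number 0.7 percentage points lower from compound 2 to compound 4 (within the scatter) and so leaves the read-out within the scatter. Nothing measured here explains these steps.

From the compounds shown here alone, compound 3 and compound 4 differ in both the chain and the ring fluorine, so which of the two matters stays open. Going by these compounds, how a butyl chain or a terminal carboxylic acid would read also stays open.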